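Ester to Ether Swap on a Shared Quinone Core

This account rests on a few compounds, and the source may have more. Where it says the series, first, only, none or still open, it means among the compounds named here.

Compound 1 `CC(C)=CC[C@@H](OC(=O)c1ccoc1)C1=CC(=O)c2c(O)ccc(O)c2C1=O`: > 100000 nM in a functional assay on DU-145 cells (Homo sapiens) for cytotoxicity, read by MTT assay; on this read-out higher numbers stand for weaker inhibition and lower numbers for stronger inhibition
Compound 2 `CC(=O)OCCC(=O)O[C@H](CC=C(C)C)C1=CC(=O)c2c(O)ccc(O)c2C1=O`: 15700 nM
Compound 3 `CC(C)=CC[C@@H](OC(=O)C1CCCOC1)C1=CC(=O)c2c(O)ccc(O)c2C1=O`: 29700 nM

The value for compound 1 is a limit of the assay, not a number (the limit of > 100000 nM in this assay, at which 1 of the 3 values shown sits). Among the two numbers shown, compound 3 sits at the top, yet the step of a 1.9-fold higher number from compound 2 to compound 3 (0.28 log units; within the scatter) lies within the scatter, so the two cannot be told apart. Compound 4 `CCC(CO[C@H](CC=C(C)C)C1=CC(=O)c2c(O)ccc(O)c2C1=O)OC` differs from compound 3 by 2-methoxybutyl in place of (oxan-3-yl)carbonyl on an oxygen on a saturated carbon. Going by the values given here, no measured step alters the carbonyl link itself; an at least 6.3-fold lower number from compound 1 to compound 2 (0.80 log units; beyond the scatter) and an at least 3.3-fold lower number from compound 1 to compound 3 (0.52 log units; beyond the scatter) change only the group on the carbonyl carbon, each at least modest. With no direct guide, no step beyond the scatter is expected in this assay. Compound 4 is therefore estimated at 25000 nM (range 8000 nM to 80000 nM), expected as a 1.2-fold lower number from compound 3 to compound 4 (0.07 log units; within the scatter).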

Compound 4, half-maximal inhibitory concentration: 45700 nM
The estimate for compound 4 lay 1.8-fold (0.26 log units) below the measured number; the measured number falls inside the stated range.
By their numbers in this assay, from the lowest: compounds 2, 3 and 4 (each within the scatter of the next, the first and the last beyond it). At a limit, above all of these: compound 1.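

The ether of compound 4 shows that this oxygen need not carry a carbonyl to keep a measurable number in this assay: with 2-methoxybutyl in place of (oxan-3-yl)carbonyl, the change stays within the scatter (a 1.5-fold higher number from compound 3 to compound 4 (0.19 log units; within the scatter)). Against the (2-acetoxyethyl)carbonyl ester, the change is modest but beyond the scatter (a 2.9-fold higher number from compound 2 to compound 4 (0.46 log units; beyond the scatter)). The value of compound 1 is a limit, so this step gives only a minimum (an at least 2.1-fold lower number from compound 1 to compound 4 (0.34 log units; beyond the scatter)): (the limit of > 100000 nM in this assay, at which 1 of the 4 values shown sits).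

The shown compounds leave open how a plain methyl or a longer chain on this oxygen would read. Going by these compounds, an amine in the 2-methoxybutyl chain also remains open.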